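Swapping the Benzyl Group for 4-Bromophenyl

A few compounds are considered here, and "the series" means these few. Any claim that something is new, unique, unknown or untested is made for them only; others in the source may bear on it.

Values in a functional assay on Caco-2 cells (Homo sapiens) for cytotoxicity, read by cell counting, with a stated time of 48 h; on this read-out lower numbers stand for stronger inhibition and higher numbers for weaker inhibition:
- Compound 1 `Cc1ccc(-n2cc(COc3cccc4cnc(Nc5cccc(Cl)c5)nc34)nn2)c([N+](=O)[O-])c1`: 37000 nM
- Compound 2 `Clc1cccc(Nc2ncc3cccc(OCc4cn(Cc5c(Cl)cccc5Cl)nn4)c3n2)c1`: 9000 nM

Compound 2, at 9000 nM, holds the lower of the two numbers in this assay. For the measured compounds named here, the only measured step is a 4.1-fold lower number from compound 1 to compound 2 (0.61 log units; beyond the scatter), and it lies beyond the usual scatter.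

Compound 3 `Clc1cccc(Nc2ncc3cccc(OCc4cn(-c5ccc(Br)cc5)nn4)c3n2)c1` has not yet been measured. It carries 4-bromophenyl in place of the 2,6-dichlorobenzyl of compound 2 on an aromatic nitrogen: 4-bromophenyl in place of 2,6-dichlorobenzyl on an aromatic nitrogen. The measured step bears on this change, as it concerns the same aromatic nitrogen and the same 2,6-dichlorobenzyl. The new change runs the opposite way, from that benzyl group to a phenyl group, but the phenyl group carries different substituents, so the guide is only a rough one. Going by a 4.1-fold lower number from compound 1 to compound 2 (0.61 log units; beyond the scatter), a modest move to a higher number is expected in this assay, and it may stay within the scatter. The expected step is a 1.8-fold higher number from compound 2 to compound 3 (0.25 log units; within the scatter). Compound 3 is estimated at 16000 nM, with an expected range of 5000 nM to 45000 nM.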

Compound 3, half-maximal inhibitory concentration: 11000 nM
Estimate against measurement, compound 3: 1.5-fold (0.16 log units) above; measured number inside the range.
By their numbers in this assay, from the lowest: compounds 2 and 3 (each within the scatter of the next); then compound 1.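

In this assay, putting 4-bromophenyl on the aromatic nitrogen in place of 2,6-dichlorobenzyl gives a 1.2-fold higher number from compound 2 to compound 3 (0.09 log units; within the scatter), so the two groups cannot be told apart at this position, even though they differ in heavy atoms, halogens and the presence of a benzyl carbon. The earlier pair could not separate a phenyl group from a benzyl group at this nitrogen, but the change from 4-methyl-2-nitrophenyl to 4-bromophenyl gives a 3.4-fold lower number from compound 1 to compound 3 (0.53 log units; beyond the scatter), showing that the higher number of compound 1 does not go with every phenyl group here: among these three compounds, it stands with 4-methyl-2-nitrophenyl alone. No evidence is at hand that would account for these numbers.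

The compounds shown leave open whether the methyl or the nitro group of compound 1 goes with its higher number, and whether the bromine of compound 3 matters at all. They also leave open how this position would respond to a group of another kind, such as an amine, a carboxylic acid or a longer alkyl chain on the same nitrogen.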